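The compounds below may be only part of what the source reports. "The series", "measured", "known", "first", "only" and "open" are said of these compounds alone.

In a functional assay on SK-MEL-28 cells (Homo sapiens) for inhibition, read by colorimetric assay and MTT assay, with a stated time of 72 h (a higher number here means a weaker inhibitor, a lower number a stronger inhibitor), compound 1 `C=CCCCCOc1ccccc1-c1cnc(OCCCC=C)n1C` gives 19000 nM and compound 2 `C=CCCCCOc1ccccc1-c1cnc(OCCCCC=C)n1C` gives 5000 nM, so compound 2 holds the lower number of the two and is the stronger inhibitor of this pair. Compound 3 `C=CCCCCCOc1ncc(-c2ccccc2OCCCCC=C)n1C` differs from compound 2 by one change, allyl in place of vinyl on a saturated chain carbon, four bonds along the chain from an oxygen on an aromatic ring. Within the data shown here, only one measured step bears on this, a 3.8-fold lower number from compound 1 to compound 2 (0.58 log units; beyond the scatter). It is the same replacement, made three bonds along the chain from the oxygen, and it is modest but beyond the scatter. One step shows no trend, so a further but smaller fall in this assay is expected. The expected change is a 2.2-fold lower number from compound 2 to compound 3 (0.34 log units; beyond the scatter). The estimate for compound 3 is 2300 nM, within an expected range of 800 nM to 6500 nM.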

Compound 3, half-maximal inhibitory concentration: 79000 nM
Beside the measured number, compound 3's estimate is 34-fold (1.54 log units) below it, and the stated range ends below it.
By their numbers in this assay, from the lowest: compound 2; then compound 1; then compound 3.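

In this assay, the replacement of vinyl by allyl does not carry one direction from place to place: the earlier gain was a 3.8-fold lower number from compound 1 to compound 2 (0.58 log units; beyond the scatter) and here the result is a 16-fold higher number from compound 2 to compound 3 (1.20 log units; beyond the scatter) in the opposite direction. Four bonds along the chain from the oxygen, the change therefore costs far more than it gained three bonds along, and the loss outruns that gain, giving a 4.2-fold higher number from compound 1 to compound 3 (0.62 log units; beyond the scatter) and leaving compound 3 the weakest of the three. Nothing available accounts for this reversal.

On these data alone, it remains open whether the rise continues with a longer chain at this place, or whether a saturated hexyl chain would behave like the hex-5-en-1-yl chain of compound 2. An amine or a carboxylic acid at the chain end also remains untested in what is shown here.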